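The source may report more compounds than this note shows. Statements on the series, on what has been measured and on what is new or still open speak of the compounds shown alone.

Measured in a functional assay on U-87MG ATCC cells for cytotoxicity against U-87 MG (Homo sapiens), read by MTT assay, with a stated time of 48 h; on this read-out lower numbers stand for stronger inhibition and higher numbers for weaker inhibition:
compound 1 `O=C(O[C@H]1C[C@H](n2cc(F)c(=O)[nH]c2=O)O[C@@H]1COP(=O)(O)Oc1cccnc1)c1ccccc1` gives 710 nM
compound 2 `C[n+]1cccc(OP(=O)([O-])OC[C@H]2O[C@@H](n3cc(F)c(=O)[nH]c3=O)C[C@@H]2OC(=O)c2ccccc2)c1` gives 590 nM

Compound 2 carries the lower of these two numbers, yet the step of a 1.2-fold lower number from compound 1 to compound 2 (0.08 log units; within the scatter) lies within the scatter, so the two compounds cannot be ranked. Compound 3 `C[N+]1(C)CCC(OP(=O)([O-])OC[C@H]2O[C@@H](n3cc(F)c(=O)[nH]c3=O)C[C@@H]2OC(=O)c2ccccc2)CC1` differs from compound 2 by a group of 8 heavy atoms (7 carbon, 1 nitrogen; one six-membered non-aromatic ring with 1 hetero atom) in place of a group of 7 heavy atoms (6 carbon, 1 nitrogen; one six-membered aromatic ring with 1 hetero atom), on an oxygen. Within the data shown here, the only measured step that bears on this exchange is the one from compound 1 to compound 2, and it showed no movement beyond the scatter. The step of a 1.1-fold higher number from compound 2 to compound 3 (0.04 log units; within the scatter) is therefore expected to stay within the scatter. Compound 3 is estimated at 650 nM, in a range from 250 nM to 1700 nM.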

Compound 3, half-maximal inhibitory concentration: 1280 nM
The estimate for compound 3 lay 2.0-fold (0.29 log units) below the measured number; low and high end bracket the measured number.
By their numbers in this assay, from the lowest: compounds 2, 1 and 3 (each within the scatter of the next, the first and the last beyond it).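

In this assay, replacing the six-membered aromatic ring with the six-membered non-aromatic ring, on an oxygen whose other neighbour is phosphorus, gave a 2.2-fold higher number from compound 2 to compound 3 (0.34 log units; beyond the scatter), the first movement beyond the scatter at this position, although both groups carry a net charge of +1. The other new step, a 1.8-fold higher number from compound 1 to compound 3 (0.26 log units; within the scatter), stays within the scatter, so compound 1 and compound 3 cannot be ranked. Nothing available bears on why the step from compound 2 occurred.

The entering group differs from the leaving one both in its ring and in its heavy-atom count, and these two changes cannot be separated here. From the compounds shown here alone, how an open-chain trimethylammonium group would read on this oxygen remains open.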